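Ethyl in Place of Cyclopropyl on the Core of Compound 3

This account rests on a few compounds, and the source may have more. Where it says the series, first, only, none or still open, it means among the compounds named here.

Of the compounds shown here, three have been measured in an assay for binding affinity to Corticotropin releasing factor receptor (Rattus norvegicus); on this read-out lower numbers stand for stronger inhibition and higher numbers for weaker inhibition. Compound 1 `CCCC(C)n1c(CC)nc2c(-c3ccc(OC)cc3C)ccnc21` gives 0.8 nM in this assay, and compound 2 `CCc1nc2c(-c3ccc(Cl)cc3Cl)ccnc2n1C(CCOC)C1CCC1` gives 2.4 nM. Compound 3 `CCC(CCOC)n1c(C2CC2)nc2c(-c3ccc(C(F)(F)F)cc3Cl)ccnc21` gives 20.8 nM, the highest of the three numbers; compound 2 stands closest to it, with a number lower by a margin beyond the scatter, and compound 1 stands furthest away. Among the measured compounds shown here, compound 3 differs from each of the other two in more than one place, so no single step among the measured compounds can be isolated from these data.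

Compound 4 `CCc1nc2c(-c3ccc(C(F)(F)F)cc3Cl)ccnc2n1C(CC)CCOC` differs from compound 3 in one place: ethyl in place of cyclopropyl on an aromatic carbon. Compounds 1 and 2 both carry ethyl at that carbon, yet they also differ from compound 4 elsewhere, so the exchange cannot be read off directly from the measured values. The step is nevertheless expected to lower the number by a modest margin, beyond the scatter: a 2.1-fold lower number from compound 3 to compound 4 (0.32 log units; beyond the scatter). Compound 4 is therefore expected to give 10 nM in this assay, with a range from 3 nM to 30 nM.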

Compound 4, inhibition constant: 0.7 nM
Compound 4: the middle estimate sits 14-fold (1.15 log units) above what was measured; measured number outside the range, below it.
By their numbers in this assay, from the lowest: compounds 4 and 1 (each within the scatter of the next); then compound 2; then compound 3.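

In this assay, ethyl in place of cyclopropyl gives a 30-fold lower number from compound 3 to compound 4 (1.47 log units; beyond the scatter), the first single change that can be read among these compounds. It shows that this aromatic carbon, between two ring nitrogen atoms, is far from indifferent to its group: the number moves strongly even though neither group carries a hydrogen-bond donor or acceptor or a net charge. Nothing measured here explains why the step is so large.

Going by these compounds, only these two groups can be compared at this carbon, so it stays open whether a methyl, a propyl chain or an amine there would keep the number of compound 4 or lose it. On these data alone, it also stays open whether the exchange gives a step of this size when the other substituents on the shared core are different.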